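This account rests on a few compounds, and the source may have more. Where it says the series, first, only, none or still open, it means among the compounds named here.

Of the compounds shown here, three with the same core have been measured in a functional assay on CCRF-CEM cells (Homo sapiens) for cytotoxicity, read by MTT assay, with a stated time of 72 h; a higher number here means a weaker inhibitor of growth, a lower number a stronger inhibitor of growth. Compound 1, `CCCCOC(=O)Nc1ccc([Se]C#N)cc1`, gives 6500 nM. Compound 2, `N#C[Se]c1ccc(NC(=O)Oc2ccc(F)cc2)cc1`, gives 12600 nM in this assay. Compound 3, `CCCCOC(=O)Nc1ccc([Se][Se]c2ccc(NC(=O)OCCCC)cc2)cc1`, which joins the core to a copy of itself through a diselenide link, gives 16700 nM in this assay.

Compound 1 has the lowest number of the three. Its gap to compound 2 lies within the usual scatter of repeated measurements, so the two cannot be ranked against each other; its gap to compound 3 lies beyond that scatter, so compound 1 is a stronger inhibitor of growth than compound 3.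

Compound 4, `CCOC(=O)Nc1ccc([Se]C#N)cc1`, has not yet been measured in this assay. It differs from compound 1 in one place: hydrogen in place of ethyl on a saturated chain carbon, two bonds along the chain from an oxygen next to a carbonyl group. The chain on the carbamate oxygen is shortened, the rest of the molecule stays the same.

Going by the values given here, no measured pair in this set shows the effect of such a shortening, so the expectation rests on the spread of the three numbers. The step of a 1.2-fold higher number from compound 1 to compound 4 (0.09 log units; within the scatter) is expected to be small, with no clear direction beyond the scatter. Compound 4 is therefore estimated at 8000 nM, with a range from 3000 nM to 20000 nM.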

Compound 4, concentration for 50% growth inhibition: 9800 nM
The estimate for compound 4 lay 1.2-fold (0.09 log units) below the measured number; the measured number falls inside the stated range.
By their numbers in this assay, from the lowest: compounds 1, 4, 2 and 3 (each within the scatter of the next, the first and the last beyond it).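

Going by these compounds alone, compound 1 and compound 4 are the first pair in this set that differ in one place only, so the length of the chain on the carbamate oxygen can now be read directly. In this assay, the pair shows a 1.5-fold higher number from compound 1 to compound 4 (0.18 log units; within the scatter) and so butoxy and ethoxy cannot be told apart at this position, which means that removing the outer ethyl portion of the butyl chain leaves growth inhibition in these cells unchanged as far as this assay can resolve. Nothing available explains why the two compounds read alike.

Within the data shown here, this comparison covers only two chain lengths, so it remains open whether the same holds for a chain as short as methyl, for a longer chain such as hexyl, or for a chain carrying an amine or a carboxylic acid. On these data alone, it also remains open whether ethoxy in place of butoxy would give an equally small step in the diselenide compound 3, or in another kind of cell.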